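A few compounds are considered here, and "the series" means these few. Any claim that something is new, unique, unknown or untested is made for them only; others in the source may bear on it.

Working notes on the series. Three compounds have numbers in a functional assay on CHO-K1 cells with Glucose-dependent insulinotropic receptor (Homo sapiens) as the target, read by a luciferase reporter, with a stated time of 5 h; on this read-out lower numbers stand for smaller maximal responses and higher numbers for larger maximal responses. Compound 1 `CC(C)c1noc(N2CCC(Oc3ncnc4c3CCN4c3ccc(S(C)(=O)=O)cc3F)CC2)n1` gives 124%. Compound 2 `Cc1nc(OC2CCN(C(=O)OC(C)(C)C)CC2)c2c(n1)N(c1ccc(S(C)(=O)=O)cc1F)CC2` gives 69%, and compound 3 `Cc1nc(OC2CCN(C(=O)OC(C)C)CC2)c2c(n1)N(c1ccc(S(C)(=O)=O)cc1F)CC2` gives 45%. Compound 3 stands lowest of the three, with compound 2 nearest and compound 1 furthest, both gaps beyond the scatter. Among the compounds with values here, the one single-point step measured so far is a number 24 percentage points lower from compound 2 to compound 3 (beyond the scatter); it shows that the group on the amine nitrogen in the ring shifts the maximal response by more than the scatter.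

Compound 4 `Cc1nc(OC2CCN(c3nc(C(C)C)no3)CC2)c2c(n1)N(c1ccc(S(C)(=O)=O)cc1F)CC2` is not yet measured. It differs from compound 3 in one place: 3-isopropyl-1,2,4-oxadiazol-5-yl in place of isopropoxycarbonyl on an amine nitrogen in a ring. Within the data shown here, no measured step covers this exact exchange, so the expectation rests on two indirect points. First, the step from an isopropoxycarbonyl group to a tert-butoxycarbonyl group was already modest but beyond the scatter, so this position is responsive. Second, compound 1 carries the same 3-isopropyl-1,2,4-oxadiazol-5-yl group on the amine nitrogen in the ring, differs from compound 4 elsewhere in the shared core, and gives the highest number of the set. Compound 4 is therefore expected to rise, a number 55 percentage points higher from compound 3 to compound 4 (beyond the scatter) in this assay. For compound 4 the estimate in this assay is 100%, with a range from 70% to 130%.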

Compound 4, largest response reached (reported as percent of maximum), in percent of the reference or control that the assay uses: 44%
Compound 4: middle estimate off by 56 percentage points, on the high side, and the stated range ends above it.
By their numbers in this assay, from the lowest: compounds 4 and 3 (each within the scatter of the next); then compound 2; then compound 1.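

In this assay, 3-isopropyl-1,2,4-oxadiazol-5-yl in place of isopropoxycarbonyl on an amine nitrogen in a ring gives a number 1 percentage points lower from compound 3 to compound 4 (within the scatter), so on this shared core the two groups cannot be told apart, and 3-isopropyl-1,2,4-oxadiazol-5-yl does not by itself bring the high response of compound 1. Within the data shown here, exchanging tert-butoxycarbonyl for the same group gives a number 25 percentage points lower from compound 2 to compound 4 (beyond the scatter), which leaves tert-butoxycarbonyl as the one group of these three that stands apart on this core. Among these compounds, with the group on the amine nitrogen held the same, methyl in place of hydrogen on an aromatic carbon gives a number 80 percentage points lower from compound 1 to compound 4 (beyond the scatter), the largest step in the set, so the single change away from that nitrogen matters more here than any exchange on it.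

Still open, going by these compounds, is whether the same loss appears with isopropoxycarbonyl or tert-butoxycarbonyl on the amine nitrogen, and how an ethyl, an amino or a methoxy group on that aromatic carbon would read out. Nothing available gives a reason for either the flat step or the large one.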